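Dropping the chloro: a solubility step expected upward

The source may hold more compounds than are shown below. What is called first, only, known or untested is meant among the compounds shown, and "the series" means these compounds.

Measured so far:
compound 1, `Cc1c(COc2ccnc(OCC3CCOCC3)c2)[nH]c2ccccc2c1=O` — 22000 nM
compound 2, `Cc1c(COc2cccc(OCC3CCOCC3)c2)[nH]c2ccc(Cl)cc2c1=O` — < 1000 nM

In a physicochemical assay for solubility, at pH 6.8 (a lower number here means a less soluble compound, a higher number a more soluble compound), compound 1 gives 22000 nM. Compound 2 gives only a limit, < 1000 nM, so its true value is not known as a number. One of the two results shown sits at that limit (the limit of < 1000 nM in this assay, at which 1 of the 2 values shown sits). Compound 3, `Cc1c(COc2cccc(OCC3CCOCC3)c2)[nH]c2ccccc2c1=O`, differs from compound 2 by hydrogen in place of chloro on an aromatic carbon. Among the compounds with values here, no measured pair separates only by this change, so the step from compound 2 to compound 3 in this assay is expected to be upward and beyond the scatter, as an at least 3.0-fold higher number from compound 2 to compound 3 (0.47 log units; beyond the scatter). Compound 3 is estimated at 3000 nM, between 800 nM and 12000 nM.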

Compound 3, solubility: 5000 nM
Estimate against measurement, compound 3: 1.7-fold (0.22 log units) below, and the stated range covers the measured number.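

In this assay, hydrogen in place of chloro on this aromatic carbon gives an at least 5.0-fold higher number from compound 2 to compound 3 (0.69 log units; beyond the scatter). This is the first pair shown that differs in only one place, so this single change can now be read on its own. As far as these compounds go, compound 2 stands only as a limit, so the full size of the step remains unknown: the limit of < 1000 nM in this assay, at which 1 of the 3 values shown sits.

The compounds shown leave open how a fluoro, a methoxy or an amine on this same carbon would compare with hydrogen and chloro. They also leave open whether the chloro change would give a similar step on a different core.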